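The compounds below may be only part of what the source reports. "The series", "measured", "known", "first", "only" and "open" are said of these compounds alone.

Measured so far in an assay on microsomes from brain for inhibition of Fatty-acid amide hydrolase 1 (Rattus norvegicus), read by fluorescence and HPLC, with a stated time of 60 min; a higher number here means a weaker inhibitor, a lower number a stronger inhibitor:
- compound 2, `O=C(COc1ccc(-c2ccccc2)cc1)Cn1nnc2ccccc21`, gives 12 nM
- compound 3, `O=C(COc1ccc(-c2ccc(F)cc2)cc1)Cn1nnc2ccccc21`, gives 12 nM
- compound 1, `CCCCCCCCc1ccc(OCC(=O)Cn2cnc3cccnc32)cc1`, gives 410 nM

Compound 3 stands level with compound 2 at the digits shown, and the two together hold the lowest numbers of the three; compound 1, with its different core, gives a markedly higher number and is the furthest away. The step from compound 2 to compound 3 reads no change at the digits printed from compound 2 to compound 3 (within the scatter), a fluoro in place of hydrogen on an aromatic carbon.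

Compound 4, `O=C(COc1ccc(-c2cccc(F)c2)cc1)Cn1nnc2ccccc21`, carries the same atoms as compound 3 joined differently: 3-fluorophenyl in place of 4-fluorophenyl on an aromatic carbon. For the measured compounds named here, only one measured step touches this region, and it is the one that brought the fluorine in; it showed nothing beyond the scatter. Going by the values given here, no measured pair shows the fluorine moved from one aromatic carbon to another, so the account rests on that single step alone. Given that compound 3 and compound 2 sit level, the expected step of a 1.2-fold higher number from compound 3 to compound 4 (0.07 log units; within the scatter) is none beyond the scatter. For compound 4 the estimate in this assay is therefore 14 nM, expected to fall between 6 nM and 35 nM.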

Compound 4, half-maximal inhibitory concentration: 14 nM
Compound 4: middle estimate and measured number agree at the digits printed; measured number inside the range.
By their numbers in this assay, from the lowest: compounds 2, 3 and 4 (each within the scatter of the next); then compound 1.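

Replacing 4-fluorophenyl with 3-fluorophenyl gives a 1.2-fold higher number from compound 3 to compound 4 (0.07 log units; within the scatter), which shows that in this assay moving the fluorine between these two places on the ring does not shift the number beyond the scatter. Measured against the unsubstituted ring, fluoro at the new place gives a 1.2-fold higher number from compound 2 to compound 4 (0.07 log units; within the scatter), so two placements of fluoro, rather than one, now stay within the scatter of the hydrogen compound. Nothing at hand explains why the number stays level.

The compounds shown leave open whether this ring accepts anything other than fluoro, such as a methoxy group, a trifluoromethyl group, an amine or a carboxylic acid, with the number still level. They also leave open whether a longer chain in place of the ring would hold the number.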